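Benzyl ether substituent swap: cyano for trifluoromethyl

A few compounds are considered here, and "the series" means these few. Any claim that something is new, unique, unknown or untested is made for them only; others in the source may bear on it.

Measured compounds:
compound 1 `CCc1cc(=O)c2ccc(OCc3ccccc3)c(C)c2o1` — > 33900 nM
compound 2 `CCc1cc(=O)c2ccc(OCc3cccc(C)c3)c(C)c2o1` — 24900 nM
compound 3 `CCc1cc(=O)c2ccc(OCc3cccc(C(F)(F)F)c3)c(C)c2o1` — > 27600 nM

In a functional assay on A549 cells (Homo sapiens) for antiproliferative activity, read by sulforhodamine B assay, with a stated time of 72 h (on this read-out higher numbers stand for weaker inhibition of growth and lower numbers for stronger inhibition of growth), compound 3 gives only a limit, (the limit of > 27600 nM in this assay, at which 1 of the 3 values shown sits). For compound 1 the value is likewise a limit, (the limit of > 33900 nM in this assay, at which 1 of the 3 values shown sits). Going by the values given here, compound 2 is the one compound with a number. The step that the two limits leave unreadable from compound 1 to compound 3 is not readable, and an at least 1.1-fold higher number from compound 2 to compound 3 (0.04 log units; that floor lies within the scatter) sits within the scatter, as does an at least 1.3-fold lower number from compound 1 to compound 2 (0.13 log units; that floor lies within the scatter).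

Compound 4 `CCc1cc(=O)c2ccc(OCc3cccc(C#N)c3)c(C)c2o1` differs from compound 3 by cyano in place of trifluoromethyl on an aromatic carbon. Among the compounds with values here, no measured step covers a cyano group; the steps that touch this ring position all stay within the scatter or are unreadable, so for this assay no step beyond the scatter is expected, an at least 1.0-fold lower number from compound 3 to compound 4 (0.02 log units; that floor lies within the scatter). Compound 4 is therefore estimated at 26000 nM, between 11000 nM and 60000 nM.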

Compound 4, concentration for 50% growth inhibition: > 31300 nM
Compound 4: a limit, no number; the forecaster's own chance of this, stated with the estimate: 40%; middle value at least 1.2-fold (0.08 log units) from the limit.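

In this assay compound 4, carrying cyano at this ring position, gives only a limit (> 31300 nM). Going by these compounds alone, the one readable step stays within the scatter (an at least 1.2-fold higher number from compound 2 to compound 4 (0.09 log units; that floor lies within the scatter)). The steps from compound 1 and from compound 3 to compound 4 cannot be read, so cyano joins hydrogen and trifluoromethyl as groups giving only a limit, with methyl in compound 2 the one exception.

Going by these compounds, whether these limits hide real differences stays open. Also open, on these data alone, is whether an amine or a carboxylic acid here would move the read-out beyond the scatter from compound 2, which gives (24900 nM).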